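This account rests on a few compounds, and the source may have more. Where it says the series, first, only, none or still open, it means among the compounds named here.

Measured so far in a functional assay on the whole organism for activation, with Mus musculus as the target; on this read-out lower numbers stand for an effect already at smaller amounts and higher numbers for an effect only at larger amounts of compound:
compound 1 `CCSc1nc(N)c2nc(O)n(Cc3ccccc3)c2n1` — 0.1 mg/kg
compound 2 `CCc1nc(N)c2nc(O)n(Cc3ccccc3)c2n1` — 3 mg/kg

For the measured compounds named here, compound 1 stands lowest of the two numbers; the only neighbour, compound 2, is reached by a 30-fold higher number from compound 1 to compound 2 (1.48 log units; beyond the scatter). Compound 3 `CSc1nc(N)c2nc(O)n(Cc3ccccc3)c2n1` differs from compound 1 by hydrogen in place of methyl on a saturated chain carbon bound to a sulfur. Going by the values given here, the single measured step puts ethyl in place of ethylsulfanyl, removing the sulfur altogether, so it does not bear directly on shortening ethylsulfanyl to methylsulfanyl; no measured step covers the present change. Keeping the sulfur and shortening the chain is expected to leave this assay within the usual scatter, no change at the digits printed from compound 1 to compound 3 (within the scatter). Compound 3 is therefore estimated at 0.1 mg/kg, with a range of 0.03 mg/kg to 0.5 mg/kg.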

Compound 3, minimum effective dose: 0.1 mg/kg
Compound 3: the middle estimate sits on the measured number at the digits printed; the range from low to high includes it.
By their numbers in this assay, from the lowest: compounds 1 and 3 (each within the scatter of the next); then compound 2.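

In this assay, shortening ethylsulfanyl to methylsulfanyl gives no change at the digits printed from compound 1 to compound 3 (within the scatter) and so shows that, on the saturated chain carbon bound to a sulfur, the methyl can be exchanged for hydrogen without a shift beyond the scatter. Methylsulfanyl in place of ethyl on the aromatic carbon gives a 30-fold lower number from compound 2 to compound 3 (1.48 log units; beyond the scatter) and so shows the large gap to compound 2 with a second sulfur chain.

Open, from the compounds shown here alone, is whether a longer chain such as propylsulfanyl, or an amine on the same aromatic carbon, holds this level. No evidence on hand speaks to the reason for either step.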